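Swapping the benzyl substituent on a nucleoside core

The source may hold more compounds than are shown below. What is called first, only, known or untested is meant among the compounds shown, and "the series" means these compounds.

Compound 1 `OC[C@H]1O[C@@H](n2cnc3c(NCc4ccccc4F)ncnc32)[C@H](O)[C@@H]1O`: > 166000 nM in a functional assay on MCF cells (Homo sapiens) for antiproliferative activity, with a stated time of 72 h; a higher number here means a weaker inhibitor, a lower number a stronger inhibitor
Compound 2 `COc1cccc(CNc2ncnc3c2ncn3[C@@H]2O[C@H](CO)[C@@H](O)[C@H]2O)c1OC`: > 166000 nM
Compound 3 `COc1ccc(CNc2ncnc3c2ncn3C2OC(CO)[C@@H](O)[C@H]2O)c(O)c1`: 2200 nM

In this assay compound 2 gives > 166000 nM, which is a limit of the assay and not a number. Compound 1 likewise gives > 166000 nM, again a limit. Compound 3 differs from compound 2 in several places; in this assay compound 3 gives 2200 nM. For the measured compounds named here, the only single change between measured compounds, a step that the two limits leave unreadable from compound 1 to compound 2, cannot be sized because both its ends sit at the limit (the limit of > 166000 nM in this assay, at which 2 of the 3 values shown sit).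

Compound 4 `OC[C@H]1O[C@@H](n2cnc3c(NCc4ccccc4OC(F)F)ncnc32)[C@H](O)[C@@H]1O` carries the change (2-(difluoromethoxy)phenyl in place of 2,3-dimethoxyphenyl on a saturated chain carbon bound to a nitrogen on an aromatic ring). Going by the values given here, two of the three measured compounds, compound 1 and compound 2, sit at the limit (the limit of > 166000 nM in this assay, at which 2 of the 3 values shown sit), and the one numerical value belongs to compound 3, which carries a hydroxyl not present in compound 4. The step of an at least 1.6-fold lower number from compound 2 to compound 4 (0.22 log units; that floor lies within the scatter) is therefore expected to stay small or unreadable. Compound 4 is estimated at 100000 nM, within 20000 nM to 300000 nM, with a fair chance that only a limit is reported.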

Compound 4, half-maximal inhibitory concentration: > 166000 nM
Compound 4: no number, only a limit; the forecaster's own chance of this, stated with the estimate: 55%; middle value at least 1.6-fold (0.22 log units) away from the limit.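

Compound 4 gives only a limit, as do compound 1 and compound 2, so no step among these three can be read: the limit of > 166000 nM in this assay, at which 3 of the 4 values shown sit.

In this assay, on these data alone, compound 3 gives 2200 nM, and which of its several differences from compound 2 goes with that value remains open.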